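Amide nitrogen swap on the shared core, affinity notes

The compounds below may be only part of what the source reports. "The series", "measured", "known", "first", "only" and "open" are said of these compounds alone.

Measured compounds:
- compound 1, `Cc1ccc2c(N=[N+]=[N-])c(Cc3ccccc3)cnc2n1`; in an assay for binding affinity to adenosine receptor A1 (Homo sapiens) (on this read-out lower numbers stand for stronger inhibition and higher numbers for weaker inhibition), compound 1 gives > 10000 nM, which is a limit of the assay rather than a number.
- compound 2, `Cc1ccc2c(O)c(C(=O)NN3CCOCC3)cnc2n1`; in this assay compound 2 gives > 10000 nM, again a limit and not a number.

Where compound 2 stands: both values shown sit at the limit of > 10000 nM in this assay, at which 2 of the 2 values shown sit, so compound 2 cannot be placed against compound 1 beyond saying both are limits. Going by the values given here, no step between measured compounds exists in this set.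

Compound 3, `Cc1ccc2c(O)c(C(=O)NC3CCC(C)CC3)cnc2n1`, is not yet measured. It differs from compound 2 by 4-methylcyclohexyl in place of morpholin-4-yl on an amide-type nitrogen. With both known values at a limit, the expected step from compound 2 to compound 3 in this assay is an at least 1.2-fold lower number from compound 2 to compound 3 (0.09 log units; that floor lies within the scatter), read as an expectation that compound 3 stays near the limit rather than a change clearly beyond the scatter. For compound 3 the estimate in this assay is 8000 nM, with a range from 2000 nM to 30000 nM; a further limit value is judged more likely than a number.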

Compound 3, inhibition constant: 5600 nM
Compound 3: middle estimate off by 1.4-fold (0.15 log units), on the high side; the measured number falls inside the stated range.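

In this assay, 4-methylcyclohexyl in place of morpholin-4-yl on an amide-type nitrogen gives an at least 1.7-fold lower number from compound 2 to compound 3 (0.25 log units; that floor lies within the scatter). Going by these compounds alone, compound 3 is the first compound here to give a number rather than a limit, so this place on the amide-type nitrogen can carry a group that yields a readable value. The step can be stated only as a floor, and its true size stays unknown, because the value of compound 2 is a limit: the limit of > 10000 nM in this assay, at which 2 of the 3 values shown sit.

With a single change at this place, the compounds shown leave open whether the number follows the carbon-only ring, the methyl group or the attachment through ring carbon rather than ring nitrogen. Plain cyclohexyl, piperidin-1-yl or a longer alkyl chain on the same nitrogen would bear on that question, and the true size of the step remains unresolved.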